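The compounds below may be only part of what the source reports. "The series", "measured", "known", "first", "only" and "open" are said of these compounds alone.

Measured in an ADME assay on microsomes from liver (Homo sapiens) for pharmacokinetics, read by LC-MS, with a stated time of 60 min, tested at 1 uM; on this read-out higher numbers stand for fast clearance and lower numbers for slow clearance:
compound 1 `O=C(NCc1ccc(S(=O)(=O)c2cccc(C(F)(F)F)c2)cc1)N1Cc2ccncc2C1` gives 14 mL/min/kg
compound 2 `CC(C)n1cc(S(=O)(=O)c2ccc(CNC(=O)N3Cc4ccncc4C3)cc2)cn1` gives 4 mL/min/kg
compound 3 `O=C(NCc1ccc(S(=O)(=O)C2CCC(F)(F)CC2)cc1)N1Cc2ccncc2C1` gives 6 mL/min/kg

Compound 3 stands with compound 2 at the low end of these numbers, and the two are not separated (a 1.5-fold higher number from compound 2 to compound 3 (0.18 log units; within the scatter)). The gap to the top number lies beyond the scatter (a 2.3-fold lower number from compound 1 to compound 3 (0.37 log units; beyond the scatter)).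

Compound 4 `O=C(NCc1ccc(S(=O)(=O)N2CCC(O)CC2)cc1)N1Cc2ccncc2C1` carries this change: 4-hydroxypiperidin-1-yl in place of 4,4-difluorocyclohexyl on a sulfonyl sulfur.

Going by the values given here, the steps that bear on it are changes at the same place. Both steps away from compound 1 were modest (a 3.5-fold lower number from compound 1 to compound 2 (0.54 log units; beyond the scatter); a 2.3-fold lower number from compound 1 to compound 3 (0.37 log units; beyond the scatter)). Among the compounds with values here, no measured compound carries the entering group, so the guide is indirect.

No step beyond the scatter is expected (a 1.2-fold lower number from compound 3 to compound 4 (0.08 log units; within the scatter)) in this assay.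

The estimate for compound 4 is 5 mL/min/kg (range 2.5 mL/min/kg to 10 mL/min/kg).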

Compound 4, clearance: 6 mL/min/kg
The estimate for compound 4 lay 1.2-fold (0.08 log units) below the measured number, within the range that was stated.
By their numbers in this assay, from the lowest: compounds 2, 3 and 4 (each within the scatter of the next); then compound 1.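

In this assay, 4-hydroxypiperidin-1-yl on the sulfonyl sulfur is not separated from 4,4-difluorocyclohexyl (no change at the digits printed from compound 3 to compound 4 (within the scatter)) or from 1-isopropyl-1H-pyrazol-4-yl (a 1.5-fold higher number from compound 2 to compound 4 (0.18 log units; within the scatter)). Among the groups shown, only 3-(trifluoromethyl)phenyl stands apart (a 2.3-fold lower number from compound 1 to compound 4 (0.37 log units; beyond the scatter)), so this position also accepts a ring with a hetero atom and a hydrogen-bond donor while staying with the low numbers. No supporting data explain this result. On these data alone, it remains open whether a carboxylic acid on the piperidine ring or an open-chain amine on the sulfonyl sulfur would also stay with compound 2, compound 3 and compound 4.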